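Swapping Carboxy for Amino on a Shared Core

The source may report more compounds than this note shows. Statements on the series, on what has been measured and on what is new or still open speak of the compounds shown alone.

Measured in an ADME assay on TZM cells (Homo sapiens) for cytotoxicity, read by XTT assay, with a stated time of 4 days; on this read-out higher numbers stand for lower toxicity in this test and lower numbers for higher toxicity in this test:
- compound 1 `Cc1cc(CCC#N)cc(C)c1Oc1cc(Nc2ccc(C#N)cc2)c(N)cc1C(=O)O` gives 14300 nM
- compound 2 `Cc1cc(N)cc(C)c1Oc1cc(Nc2ccc(C#N)cc2)c(N)cc1C(F)(F)F` gives 15800 nM
- compound 3 `Cc1cc(/C=C/C#N)cc(C)c1Oc1cc(Nc2ccc(C#N)cc2)c(N)cc1[N+](=O)[O-]` gives > 24400 nM, which is a limit of the assay and not a number

Only two of these results are true numbers. Compound 1 at 14300 nM and compound 2 at 15800 nM lie within the usual scatter of each other, so neither can be ranked above the other. Compound 3 is known only by its limit of > 24400 nM.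

The next compound is compound 4 `Cc1cc(CCC#N)cc(C)c1Oc1cc(Nc2ccc(C#N)cc2)c(N)cc1N`, not yet measured. It differs from compound 1 in a single place: amino in place of carboxy on an aromatic carbon. In words, this is amino in place of carboxy on an aromatic carbon.

Going by the values given here, no measured pair shows this change on its own, so the expectation rests on two neighbouring results. One is compound 1 at 14300 nM. The other is compound 2 at 15800 nM, which has trifluoromethyl instead of carboxy and differs elsewhere too. In this assay, the expected step of a 1.2-fold lower number from compound 1 to compound 4 (0.08 log units; within the scatter) is slightly downward and no larger than the usual scatter. For compound 4 the estimated value is 12000 nM, with an expected range from 4500 nM to 28000 nM.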

Compound 4, half-maximal cytotoxic concentration: > 25000 nM
Compound 4: no number, only a limit (the forecaster's own chance of this, stated with the estimate: 20%); middle value at least 2.0-fold (0.31 log units) away from the limit.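

The value of compound 4 is a limit of the assay and not a number: the limit of > 25000 nM in this assay, at which 1 of the 4 values shown sits.

In this assay, amino in place of carboxy on this aromatic carbon, which is ortho to a large group and para to the (4-cyanophenyl)amino group, gives an at least 1.7-fold higher number from compound 1 to compound 4 (0.24 log units; that floor lies within the scatter). Going by these compounds alone, this is the first time the change can be read on its own, with nothing else in the molecule altered, and it gives no sign of higher toxicity in this test when amino takes the place of carboxy. The true size of the step cannot be told, however: the real number for compound 4 could lie within the usual scatter of compound 1 or well beyond it.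

The compounds shown leave open whether other groups at this position, such as a hydroxyl, a methoxy or a methyl ester, would read the same way. They also leave open whether the step would hold if the chain ending in a nitrile on the other ring were replaced by a longer chain or an amide.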